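This account rests on a few compounds, and the source may have more. Where it says the series, first, only, none or still open, it means among the compounds named here.

Of the compounds shown here, three built on one shared core have been tested in a functional assay on PC-3 cells (Homo sapiens) for inhibition; on this read-out higher numbers stand for weaker inhibition and lower numbers for stronger inhibition. Compound 1 `CCn1c(=O)/c(=C2\Sc3ccc(OC)cc3N2C)s/c1=C\c1ccncc1Nc1ccccc1C` gives 370 nM in this assay. Compound 2 `CCn1c(=O)/c(=C2\Sc3ccc(C)cc3N2C)s/c1=C\c1ccncc1Nc1ccccc1C` gives 330 nM in this assay. Compound 3 `CCn1c(=O)/c(=C2\Sc3ccc(C)cc3N2C)s/c1=C\c1ccncc1Nc1ccccc1F` gives 70 nM in this assay, the lowest of the three numbers, and its distance to each of the other two lies beyond the usual scatter.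

Two single changes connect these compounds. The first, (methoxy in place of methyl on an aromatic carbon), produced a 1.1-fold higher number from compound 2 to compound 1 (0.05 log units; within the scatter), so compounds 1 and 2 cannot be told apart on this read-out. The second produced a 4.7-fold lower number from compound 2 to compound 3 (0.67 log units; beyond the scatter).

Compound 4 `CCn1c(=O)/c(=C2\Sc3ccc(OC)cc3N2C)s/c1=C\c1ccncc1Nc1ccccc1F` has not yet been measured in this assay. It differs from compound 3 by methoxy in place of methyl on an aromatic carbon. Going by the values given here, this is the same change as the one from compound 2 to compound 1, made at the same place on the core; the two starting points, compound 2 and compound 3, differ from each other by fluoro in place of methyl on an aromatic carbon.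

Since the same change already gave a 1.1-fold higher number from compound 2 to compound 1 (0.05 log units; within the scatter) on the related pair, a step of similar size is expected here, and for compound 4 in this assay the estimate means a 1.1-fold higher number from compound 3 to compound 4 (0.06 log units; within the scatter), resting on compound 3 at 70 nM as the starting value. Compound 4 is therefore expected to give about 80 nM in this assay, most likely falling between 40 nM and 160 nM.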

Compound 4, half-maximal inhibitory concentration: 100 nM
The estimate for compound 4 lay 1.3-fold (0.10 log units) below the measured number; the measured number falls inside the stated range.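

In this assay, methoxy in place of methyl on an aromatic carbon gave a 1.4-fold higher number from compound 3 to compound 4 (0.15 log units; within the scatter), so this swap again made no clear difference on the second core, just as it had on the first: the same change on two cores in this assay, a 1.1-fold higher number (0.05 log units; within the scatter) from compound 2 to compound 1 and a 1.4-fold higher number (0.15 log units; within the scatter) from compound 3 to compound 4, 1.3-fold (0.11 log units) apart, within the scatter of two such steps. Fluoro in place of methyl on an aromatic carbon gave a 3.7-fold lower number from compound 1 to compound 4 (0.57 log units; beyond the scatter), so this swap gave a clear gain in inhibition whether the methyl or the methoxy group was present on the other part of the molecule, and its size held as well: the same change on two cores in this assay, a 4.7-fold lower number (0.67 log units; beyond the scatter) from compound 2 to compound 3 and a 3.7-fold lower number (0.57 log units; beyond the scatter) from compound 1 to compound 4, 1.3-fold (0.11 log units) apart, within the scatter of two such steps. Across these four compounds, then, each change behaved the same way on both cores, but two pairs in a single assay cannot show that this holds across the wider series, and they do not explain why the fluoro swap matters while the methoxy swap does not.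

The compounds shown leave open what other groups would do at these two places, such as an amine or a carboxylic acid in place of the methoxy, or chloro or a longer chain such as ethyl in place of the fluoro. They also leave open whether the fluoro step would keep its size alongside such an amine or carboxylic acid, rather than alongside methyl or methoxy.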